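Chain variants of a shared core at the limit

A few compounds are considered here, and "the series" means these few. Any claim that something is new, unique, unknown or untested is made for them only; others in the source may bear on it.

Measured in an ADME assay on MCF7 cells (Homo sapiens) for cytotoxicity, read by CellTiter-Glo, with a stated time of 24 h (a lower number here means a stronger inhibitor of growth, a higher number a weaker inhibitor of growth), as follows:
- compound 1 `CC1=C(C(=O)OCc2ccccc2)C(c2ccc(Cl)cc2Cl)NC(=O)N1CCCCC(=O)O` gives > 100000 nM as a limit
- compound 2 `CC1=C(C(=O)OCc2ccccc2)C(c2ccc(Cl)cc2Cl)NC(=O)N1CCCC(=O)OCC1CC1` gives > 100000 nM as a limit
- compound 3 `COCCOC(=O)CCCN1C(=O)NC(c2ccc(Cl)cc2Cl)C(C(=O)OCc2ccccc2)=C1C` gives > 100000 nM as a limit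

Compound 3 stands at > 100000 nM as a limit and has no number of its own. The whole set reads alike, with the limit of > 100000 nM in this assay, at which 3 of the 3 values shown sit, as the only level seen so far.

The next change leads to compound 4 `COC(=O)CCCCN1C(=O)NC(c2ccc(Cl)cc2Cl)C(C(=O)OCc2ccccc2)=C1C` and is (methoxycarbonyl)methyl in place of (2-methoxyethoxy)carbonyl on a saturated chain carbon, three bonds along the chain from an amide-type nitrogen in a ring in the form of (methoxycarbonyl)methyl in place of (2-methoxyethoxy)carbonyl on a saturated chain carbon, three bonds along the chain from an amide-type nitrogen in a ring.

The steps bearing on this place are a step that the two limits leave unreadable from compound 1 to compound 3 and a step that the two limits leave unreadable from compound 2 to compound 3 together with a step that the two limits leave unreadable from compound 1 to compound 2 and none of them has a readable size. Resting on compound 3 and a step that the two limits leave unreadable from compound 1 to compound 3 no direction can be drawn, so in this assay no step beyond the scatter is expected. The expected step is a number no higher from compound 3 to compound 4 (the limit leaves the size open) as estimated here. For compound 4 the estimate is 100000 nM with an expected range of 50000 nM to 200000 nM in this estimate.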

Compound 4, concentration for 50% growth inhibition: > 100000 nM
Compound 4: a limit, no number (the forecaster's own chance of this, stated with the estimate: 90%); the middle value sits exactly at the limit.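

In this assay, within the data shown here, compound 4 gives > 100000 nM, a limit, so no step linking compounds 1, 2, 3 and 4 can be read. The compounds shown leave open whether any chain variant on the shared core reaches a measurable number in this assay, and how these chains would then rank.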